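Swapping one side chain: how much compound remains?

This account rests on a few compounds, and the source may have more. Where it says the series, first, only, none or still open, it means among the compounds named here.

Measured so far in an ADME assay on S9 fraction from liver (Rattus norvegicus) for metabolic stability, with a stated time of 1 h (a lower number here means that less of the compound is left, a higher number that more of the compound is left), are three compounds
compound 1 `CO[C@H]1CC[C@@H](CNc2cc(NCc3cnccc3C(F)(F)F)ncc2C#N)CC1` gives 2%
compound 2 `N#Cc1cnc(NCc2cnccc2C(F)(F)F)cc1NC1CCOCC1` gives 17%
compound 3 `N#Cc1cnc(NCc2cnccc2C(F)(F)F)cc1NCCC1CCOCC1` gives 0%

Compound 3 stands level with compound 1 and clearly short of compound 2. The measurements show a number 2 percentage points lower from compound 1 to compound 3 (within the scatter) and a number 17 percentage points lower from compound 2 to compound 3 (beyond the scatter) in this read-out.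

Compound 4 `CNC(=O)[C@H]1CC[C@@H](Nc2cc(NCc3cnccc3C(F)(F)F)ncc2C#N)CC1` keeps the shared core and differs from compound 3 in one place, with 4-(methylcarbamoyl)cyclohexyl in place of 2-(oxan-4-yl)ethyl on a nitrogen on an aromatic ring as the full count of that change. In short, 4-(methylcarbamoyl)cyclohexyl replaces 2-(oxan-4-yl)ethyl on a nitrogen on an aromatic ring.

Among the measured compounds shown here, no measured step makes this exact swap, so only related steps can guide the estimate. Changes on the same nitrogen gave a number 15 percentage points higher from compound 1 to compound 2 (beyond the scatter) as well as a number 17 percentage points lower from compound 2 to compound 3 (beyond the scatter) and both are modest. Like compound 4, compound 2 carries its ring on that nitrogen without a chain and gives 17% in this assay as the encouraging precedent. Compound 1 also has a ring of carbon only and gives 2% as the cautionary one.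

A modest rise is therefore expected, and the estimated move is a number 15 percentage points higher from compound 3 to compound 4 (beyond the scatter) in this assay overall. For the measured compounds named here, no measured compound carries this amide, so the range stays wide. In this assay compound 4 is expected at 15% with an estimated range from 2% to 40% for the coming measurement.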

Compound 4, percent of the compound remaining: 53%
Beside the measured number, compound 4's estimate is 38 percentage points below it, outside the stated range (above it).
By their numbers in this assay, from the lowest: compounds 3 and 1 (each within the scatter of the next); then compound 2; then compound 4.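

In this assay, the nitrogen on an aromatic ring proves able to hold a side chain that leaves far more compound than any earlier one, with a number 53 percentage points higher from compound 3 to compound 4 (beyond the scatter) and a number 36 percentage points higher from compound 2 to compound 4 (beyond the scatter) and also a number 51 percentage points higher from compound 1 to compound 4 (beyond the scatter) as the three steps to 4-(methylcarbamoyl)cyclohexyl. The earlier changes at this place had reached no further than compound 2 at 17% and so gave no sign of a rise this large, while compound 1 at 2% shows that a ring of carbon only does not by itself go with a high number. Why this group stands so far apart from the others remains unexplained, as nothing measured here bears on the cause.

Compound 4 differs from each earlier compound in the whole side chain, so the compounds shown cannot separate the part played by the methylcarbamoyl group from that of the directly attached cyclohexyl ring. On these data alone, it also stays open whether a primary amide or a carboxylic acid on the same cyclohexyl ring, or a methylcarbamoyl group on a longer chain, would keep this much compound in this assay as well.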